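The compounds below may be only part of what the source reports. "The series", "measured", "known", "first", "only" and "open" are said of these compounds alone.

Compound 1 `N#CC1=C(N)Oc2c(c3nc4ccccc4nc3c3ccccc23)C12C(=O)N(Cc1cnnn1-c1cccc(Cl)c1)c1ccccc12` gives 32600 nM in a functional assay on A549 cells (Homo sapiens) for antiproliferative activity, read by MTT assay, with a stated time of 48 h; a lower number here means a stronger inhibitor, a higher number a weaker inhibitor.
Compound 2 `Cc1ccc(-n2nncc2CN2C(=O)C3(C(C#N)=C(N)Oc4c3c3nc5ccccc5nc3c3ccccc43)c3ccccc32)cc1Cl` reaches only the limit of this assay, reported as > 50000 nM.
Compound 3 `N#CC1=C(N)Oc2c(N)cc3nc4ccccc4nc3c2C12C(=O)N(Cc1cnnn1-c1ccccc1Cl)c1ccccc12` gives 29800 nM in this assay.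

Compound 3 thus holds the lowest of the two numbers shown; its nearest neighbour is compound 1, whose number is higher by an amount within the scatter, and the remaining value is a limit rather than a number. Compound 4 `N#CC1=C(N)Oc2c(N)cc3nc4ccccc4nc3c2C12C(=O)N(Cc1cnnn1-c1ccc(Cl)cc1Cl)c1ccccc12` differs from compound 3 by chloro in place of hydrogen on an aromatic carbon. Among the measured compounds shown here, the only measured step that resembles it is an at least 1.5-fold higher number from compound 1 to compound 2 (0.18 log units; that floor lies within the scatter), also a swap on an aromatic carbon, and it is tied to the limit (the limit of > 50000 nM in this assay, at which 1 of the 3 values shown sits), so its true size is unknown. No step beyond the scatter is therefore expected in this assay. Compound 4 is estimated at 32000 nM, between 12000 nM and 90000 nM. This corresponds to an expected step of a 1.1-fold higher number from compound 3 to compound 4 (0.03 log units; within the scatter).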

Compound 4, half-maximal inhibitory concentration: > 50000 nM
Compound 4 was reported as a limit; the forecaster's own chance of this, stated with the estimate: 25%; middle value at least 1.5-fold (0.19 log units) from the limit.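

In this assay, chloro in place of hydrogen, turning 2-chlorophenyl into 2,4-dichlorophenyl, gives an at least 1.6-fold higher number from compound 3 to compound 4 (0.22 log units; that floor lies within the scatter). The result for compound 4 is a limit and not a number, so the true size of this step cannot be read: the limit of > 50000 nM in this assay, at which 2 of the 4 values shown sit. What it does show is that adding this second chloro, para to a large group, brings no lower number. As far as these compounds go, how an amine or a methoxy group at this position would read in this assay remains open. So does how a plain phenyl group would compare with the 2-chlorophenyl group of compound 3.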